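Notes on the amide substituent: compound 3 to compound 4

This account rests on a few compounds, and the source may have more. Where it says the series, first, only, none or still open, it means among the compounds named here.

Measured in an in vitro ADME assay on microsomes from liver (Mus musculus) for pharmacokinetics, read by LC-MS, with a stated time of 10 min, tested at 1 uM; on this read-out lower numbers stand for slow clearance and higher numbers for fast clearance:
- compound 1 `CN1C[C@H](C(=O)Nc2ccc(C3CC3)cc2)[C@@H](c2ccc(/C=C/C(=O)Nc3ccccc3N)cc2)C1`: 60 mL/min/kg
- compound 2 `Cc1cccc(NC(=O)[C@H]2CN(C)C[C@@H]2c2ccc(/C=C/C(=O)Nc3ccccc3N)cc2)c1`: 74 mL/min/kg
- compound 3 `CN1C[C@H](C(=O)Nc2ccc(Cl)c(Cl)c2)[C@@H](c2ccc(/C=C/C(=O)Nc3ccccc3N)cc2)C1`: 36 mL/min/kg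

Compound 3 lies within the scatter of one measured neighbour and beyond it of the other. The two steps are a 1.7-fold lower number from compound 1 to compound 3 (0.22 log units; within the scatter), and a 2.1-fold lower number from compound 2 to compound 3 (0.31 log units; beyond the scatter). Still open, on these data alone, is compound 4 `CN1C[C@H](C(=O)Nc2ccc(Cl)cn2)[C@@H](c2ccc(/C=C/C(=O)Nc3ccccc3N)cc2)C1`, which carries 5-chloropyridin-2-yl in place of 3,4-dichlorophenyl on an amide-type nitrogen. Both steps changed the group at this same place, and both were small. Neither brought in a ring with a hetero atom, so the direction is poorly defined. The expected outcome is a 1.3-fold higher number from compound 3 to compound 4 (0.10 log units; within the scatter), with no clear change anticipated in this assay. For compound 4 the estimated value is 45 mL/min/kg, with an expected range of 25 mL/min/kg to 80 mL/min/kg.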

Compound 4, clearance: 31 mL/min/kg
The estimate for compound 4 lay 1.5-fold (0.16 log units) above the measured number, within the range that was stated.
By their numbers in this assay, from the lowest: compounds 4, 3, 1 and 2 (each within the scatter of the next, the first and the last beyond it).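

In this assay the first ring with a hetero atom at this place, 5-chloropyridin-2-yl, gives a 1.2-fold lower number from compound 3 to compound 4 (0.06 log units; within the scatter) against 3,4-dichlorophenyl, so a ring nitrogen in place of a ring carbon, with one chlorine fewer, moves the number by no more than the scatter. The wider steps are a 2.4-fold lower number from compound 2 to compound 4 (0.38 log units; beyond the scatter) and a 1.9-fold lower number from compound 1 to compound 4 (0.29 log units; within the scatter) and only the first of these passes the scatter. Nothing at hand accounts for these numbers.

The ring nitrogen and the lost chlorine change together here and cannot be told apart. On these data alone, how an amine or a carboxylic acid on this ring would read remains open.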